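Carbonyl substituent swap in a small amine series

The source may report more compounds than this note shows. Statements on the series, on what has been measured and on what is new or still open speak of the compounds shown alone.

Measured so far:
compound 1, `COC(=O)N1CC2CNCC2C1` — 85%
compound 2, `COC(=O)[C@H]1C[C@H]2CNC[C@H]2C1` — 100%
compound 3, `O=C(c1ccco1)[C@H]1C[C@@H]2CNC[C@@H](C2)C1` — "not determined" (no result reported)

In an assay on CHO cells for agonist activity at Neuronal acetylcholine receptor; alpha3/beta4 (Homo sapiens), read by FLIPR and calcium flux (on this read-out lower numbers stand for smaller maximal responses and higher numbers for larger maximal responses), compound 1 gives 85% and compound 2 gives 100%. The two values lie within the usual scatter of one another, so no order between compound 1 and compound 2 is claimed; both reach a large maximal response. Compound 3 gives "not determined" (no result reported) in this assay, so there is no number to place it against compound 1 or compound 2, and its standing in the series is open.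

Compound 4, `CCCNC(=O)[C@H]1C[C@@H]2CNC[C@@H](C2)C1`, differs from compound 3 in one place: propylamino in place of furan-2-yl on a carbonyl carbon. For the measured compounds named here, no step between two measured compounds carries this change, so its size and direction in this assay cannot be read from the data, and with compound 3 unmeasured no step from compound 3 to compound 4 can be estimated at all.

What remains is the level set by compound 1 and compound 2, both of which give a large maximal response in this assay. Going by these compounds, on that basis alone compound 4 is expected to reach about 85% in this assay, with a range from 50% to 110%, the width reflecting that the change itself is untested.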

Compound 4, largest response reached (Emax), in percent of the reference or control that the assay uses: 24%
Compound 4: the middle estimate sits 61 percentage points above what was measured; measured number below the stated range.
By their numbers in this assay, from the lowest: compound 4; then compound 1; then compound 2.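

For the compounds shown here, no step from compound 3 to compound 4 can be read in this assay, where compound 4 gives 24% and compound 3 gives "not determined" (no result reported). The compounds shown leave open what propylamino in place of furan-2-yl on a carbonyl carbon does to the maximal response. No evidence bearing on the result of compound 4 is available.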